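The source may report more compounds than this note shows. Statements on the series, on what has been measured and on what is new or still open speak of the compounds shown alone.

Measured so far in a functional assay on MCF7 cells (Homo sapiens) for inhibition, read by sulforhodamine B assay, with a stated time of 72 h; a lower number here means a stronger inhibitor, a higher number a weaker inhibitor:
compound 1 `Cc1ccc(C2=Nn3c(nnc3C(C)c3ccc(CC(C)C)cc3)SC2)cc1`: 6300 nM
compound 2 `COc1ccc2cc(C(C)c3nnc4n3N=C(c3ccc(OC(F)(F)F)cc3)CS4)ccc2c1`: 8800 nM
compound 3 `COc1ccc2cc(C(C)c3nnc4n3N=C(c3ccc(F)cc3)CS4)ccc2c1`: 15800 nM

Compound 1 lies within the scatter of compound 2 and beyond the scatter from compound 3, whose number is the higher. Compound 4 `CC(C)Cc1ccc(C(C)c2nnc3n2N=C(c2ccc(OC(F)(F)F)cc2)CS3)cc1` differs from compound 1 in one place: trifluoromethoxy in place of methyl on an aromatic carbon. Among the measured compounds shown here, the only measured step involving that group, a 1.8-fold higher number from compound 2 to compound 3 (0.25 log units; within the scatter), stays within the scatter, and it exchanges trifluoromethoxy for fluoro, not methyl, so it is only an indirect guide. No change beyond the scatter is therefore expected in this assay, and the estimated step is a 1.1-fold lower number from compound 1 to compound 4 (0.02 log units; within the scatter). Compound 4 is expected at about 6000 nM, within an estimated range of 2800 nM to 13000 nM.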

Compound 4, half-maximal inhibitory concentration: 1100 nM
The estimate for compound 4 lay 5.5-fold (0.74 log units) above the measured number; the measured number lies below the stated range.
By their numbers in this assay, from the lowest: compound 4; then compounds 1, 2 and 3 (each within the scatter of the next, the first and the last beyond it).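

In this assay trifluoromethoxy in place of methyl gives a 5.7-fold lower number from compound 1 to compound 4 (0.76 log units; beyond the scatter) and so shows that this position, para to a large group, responds to the group it carries. The earlier step, a 1.8-fold higher number from compound 2 to compound 3 (0.25 log units; within the scatter) stays within the scatter, but it exchanges a different pair of groups on a different remainder of the molecule. Nothing shown gives a measured reason for the lower number. Open, on these data alone, is how an amine, a carboxylic acid or a longer chain would fare at this position. Also open, as far as these compounds go, is whether the same exchange gives a similar step when the other end of the molecule is that of compound 2.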